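Growth inhibition notes: a change on the carbonyl carbon

The compounds below may be only part of what the source reports. "The series", "measured", "known", "first", "only" and "open" are said of these compounds alone.

compound 1 `COc1ccc2c(c1)c(-c1nc3ccccc3n1C(=O)c1ccccc1OC)cn2C` gives 23600 nM
compound 2 `COc1ccccc1C(=O)n1c(-c2cn(C)c3ccc(Br)cc23)nc2ccccc21` gives 34600 nM

Compound 2 stands within the scatter of compound 1, so neither can be ranked in a functional assay on HepG2 cells (Homo sapiens) for inhibition, read by MTT assay, with a stated time of 24 h (on this read-out lower numbers stand for stronger inhibition of growth and higher numbers for weaker inhibition of growth), on these two values alone. The next compound, compound 3 `COc1ccc(C(=O)n2c(-c3cn(C)c4ccc(Br)cc34)nc3ccccc32)cc1OC` keeps the core of compound 2 and differs in one place: 3,4-dimethoxyphenyl in place of 2-methoxyphenyl on a carbonyl carbon is the counted difference. In words, this is 3,4-dimethoxyphenyl in place of 2-methoxyphenyl on a carbonyl carbon. Within the data shown here, the one measured step, a 1.5-fold higher number from compound 1 to compound 2 (0.17 log units; within the scatter) for bromo in place of methoxy on an aromatic carbon, lies at another place and is only a weak guide to this change. Among the measured compounds shown here, no step has been measured on the carbonyl carbon. With compound 2 at 34600 nM as the starting value, no step beyond the scatter is expected in this assay and no direction is favoured. The estimate means an expected 1.2-fold lower number from compound 2 to compound 3 (0.06 log units; within the scatter) in this series. Compound 3 is estimated at 30000 nM within an expected range of 12000 nM to 75000 nM for now.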

Compound 3, concentration for 50% growth inhibition: 9700 nM
Beside the measured number, compound 3's estimate is 3.1-fold (0.49 log units) above it; measured number outside the range, below it.
By their numbers in this assay, from the lowest: compound 3; then compounds 1 and 2 (each within the scatter of the next).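

Notes on the carbonyl carbon: this is the first place in the series where a single change moves the number beyond the scatter. In this assay 3,4-dimethoxyphenyl in place of 2-methoxyphenyl gives a 3.6-fold lower number from compound 2 to compound 3 (0.55 log units; beyond the scatter) on the bromo-bearing core, so the aryl group on the carbonyl carbon influences growth inhibition in this read-out, and a modest gain is possible there. Among these compounds, the only other step, a 1.5-fold higher number from compound 1 to compound 2 (0.17 log units; within the scatter) for bromo in place of methoxy on an aromatic carbon, stayed within the scatter, and no information at hand accounts for the step at the carbonyl carbon.

The change swaps one whole aryl group for another, so the compounds shown cannot separate the loss of 2-methoxyphenyl from the gain of 3,4-dimethoxyphenyl, and they do not show whether the same swap would carry over to the methoxy-bearing core of compound 1. As far as these compounds go, it also remains open how the number would respond to an unsubstituted phenyl on the carbonyl carbon, or to an amine or a carboxylic acid on that aryl group in place of the methoxy groups.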